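Cyclohexyl in place of methoxyphenyl on a shared core

The compounds below may be only part of what the source reports. "The series", "measured", "known", "first", "only" and "open" are said of these compounds alone.

Compound 1 `COc1ccc(NC2=CC(=O)c3c(nc4n3[C@H]3OC[C@@H](O)[C@H]3OC4)C2=O)cc1` is tested in a functional assay on HeLa cells (Homo sapiens) for inhibition, read by sulforhodamine B assay; on this read-out higher numbers stand for weaker inhibition and lower numbers for stronger inhibition. In this assay compound 1 gives > 8000 nM, which is a limit of the assay and not a number. Compound 2 `O=C1C=C(NCc2ccccc2)C(=O)c2c1nc1n2[C@H]2OC[C@@H](O)[C@H]2OC1` and compound 3 `O=C1C=C(NC2CCCC2)C(=O)c2c1nc1n2[C@H]2OC[C@@H](O)[C@H]2OC1` carry the same core with other groups on the amine nitrogen. In this assay compound 2 gives > 8000 nM, again a limit. Compound 3 gives > 16000 nM in this assay, also a limit. Every value shown is a limit (the limit of > 16000 nM in this assay, at which 1 of the 3 values shown sits, (the limit of > 8000 nM in this assay, at which 2 of the 3 values shown sit)), so compound 1 stands at a limit alongside the others and cannot be placed more finely among them. Compound 4 `O=C1C(NC2CCCCC2)=CC(=O)c2c1nc1n2[C@H]2OC[C@@H](O)[C@H]2OC1` differs from compound 1 by cyclohexyl in place of 4-methoxyphenyl on an amine nitrogen. Among the compounds with values here, the only measured step, a step that the two limits leave unreadable from compound 2 to compound 3, likewise puts a non-aromatic ring of carbon only onto the amine nitrogen, but its size is not readable. No step beyond the scatter can be foreseen, and compound 4 is expected to remain at a limit as well. The estimate for compound 4 is 20000 nM, from 8000 nM to 60000 nM, an expected step that the limit leaves unreadable from compound 1 to compound 4.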

Compound 4, half-maximal inhibitory concentration: > 16000 nM
Compound 4: a limit, no number; the forecaster's own chance of this, stated with the estimate: 85%; the middle value lies beyond the limit too.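

Within the data shown here, compound 1 and compound 4 both stand at limits of this assay, and no step between them can be read. The compounds shown leave open whether any group on the amine nitrogen of the shared core gives a measurable half-maximal inhibitory concentration.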